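The source may hold more compounds than are shown below. What is called first, only, known or untested is meant among the compounds shown, and "the series" means these compounds.

All three compounds that have been measured share one core and differ only in the group attached to an aromatic carbon of the five-membered ring with three nitrogens. Compound 1 `O=C1O[C@H]([C@@H](O)Cn2cc(-c3cc(F)cc(F)c3)nn2)C(OCc2ccccc2)=C1OCc1ccccc1` carries a 3,5-difluorophenyl there and gives 27700 nM in a functional assay on MCF7 cells (Homo sapiens) for antiproliferative activity, read by MTT assay, with a stated time of 72 h; a lower number here means a stronger inhibitor, a higher number a weaker inhibitor. Compound 2 `COc1ccccc1-c1cn(C[C@H](O)[C@H]2OC(=O)C(OCc3ccccc3)=C2OCc2ccccc2)nn1` carries a 2-methoxyphenyl, and its result in this assay is only a limit, > 100000 nM, as the limit of > 100000 nM in this assay, at which 1 of the 3 values shown sits, records. Compound 3 `CCCCCc1ccc(-c2cn(C[C@H](O)[C@H]3OC(=O)C(OCc4ccccc4)=C3OCc3ccccc3)nn2)cc1`, with a 4-pentylphenyl, gives 9010 nM in this assay, the lowest number among the compounds with a measured value.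

Compound 4 `O=C1O[C@H]([C@@H](O)Cn2ccnn2)C(OCc2ccccc2)=C1OCc1ccccc1` removes the aryl group altogether: hydrogen in place of 4-pentylphenyl on an aromatic carbon. The measured steps point one way. There was a 3.1-fold lower number from compound 1 to compound 3 (0.49 log units; beyond the scatter) and an at least 11-fold lower number from compound 2 to compound 3 (1.04 log units; beyond the scatter), so the larger 4-pentylphenyl gave lower numbers than either smaller aryl group. Taking the group away entirely is therefore expected to raise the number, likely by a step at least as large as those seen, with a fair chance that only a limit is reported. Compound 4 is expected to give about 60000 nM in this assay, within a range from 20000 nM to 150000 nM, meaning a 6.7-fold higher number from compound 3 to compound 4 (0.82 log units; beyond the scatter).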

Compound 4, half-maximal inhibitory concentration: > 100000 nM
Compound 4 ended at the assay's limit; the forecaster's own chance of this, stated with the estimate: 35%; middle value at least 1.6-fold (0.22 log units) away from the limit.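

Replacing the aryl group with hydrogen on this aromatic carbon shows what that group contributes: in this assay, there is an at least 11-fold higher number from compound 3 to compound 4 (1.04 log units; beyond the scatter), and there is also an at least 3.6-fold higher number from compound 1 to compound 4 (0.55 log units; beyond the scatter). Among the compounds shown, the shared core with no aryl group gives no value below the limit, so a measurable number here depends on the group at this position; having an aryl group is not enough, however, and compound 2 goes against any simple rule, since it carries one and still gives no number. Compound 2 and compound 4 therefore cannot be ranked, and the step between them cannot be read: the limit of > 100000 nM in this assay, at which 2 of the 4 values shown sit.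

The compounds shown leave open whether the ring of the 4-pentylphenyl matters, or whether a plain pentyl chain on this carbon would serve as well. They also leave open whether a longer chain on the phenyl ring would lower the number further.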